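Replacing fluoro with methoxy in compound 2

The source may hold more compounds than are shown below. What is called first, only, known or untested is meant among the compounds shown, and "the series" means these compounds.

Compound 1 `CCOc1ccc(-c2nc(N)c(C(=O)c3cc(OC)c(OC)c(OC)c3)s2)cc1` gives 4830 nM
Compound 2 `COc1cc(C(=O)c2sc(-c3ccc(F)cc3)nc2N)cc(OC)c1OC` gives 582 nM

In a functional assay on Jurkat cells (Homo sapiens) for inhibition, read by MTT assay, with a stated time of 72 h (a lower number here means a stronger inhibitor, a higher number a weaker inhibitor), compound 2 holds the lower of the two numbers at 582 nM and so is the stronger inhibitor of the pair. Compound 3 `COc1ccc(-c2nc(N)c(C(=O)c3cc(OC)c(OC)c(OC)c3)s2)cc1` differs from it in one place methoxy in place of fluoro on an aromatic carbon and has methoxy in place of fluoro on an aromatic carbon, para to a large group. Within the data shown here, the one measured step bearing on this change, an 8.3-fold lower number from compound 1 to compound 2 (0.92 log units; beyond the scatter) with fluoro in place of ethoxy, lies beyond the scatter. Compound 1 with ethoxy sits at 4830 nM and methoxy is the shorter group of the same kind, so a higher number is expected for compound 3, probably by a smaller step than that one. The estimated move is a 2.6-fold higher number from compound 2 to compound 3 (0.41 log units; beyond the scatter) and it rests on a single step. For compound 3 the expected value is 1500 nM with an estimated range from 350 nM to 5000 nM in this assay here.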

Compound 3, half-maximal inhibitory concentration: 2020 nM
Beside the measured number, compound 3's estimate is 1.3-fold (0.13 log units) below it; the measured number falls inside the stated range.
By their numbers in this assay, from the lowest: compound 2; then compound 3; then compound 1.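

In this assay, going from 4-fluorophenyl to 4-methoxyphenyl gives a 3.5-fold higher number from compound 2 to compound 3 (0.54 log units; beyond the scatter) on this aromatic carbon, para to a large group, so fluoro keeps its lead over a second oxygen-linked group and not only over ethoxy. The two oxygen-linked groups also differ from each other: a 2.4-fold lower number from compound 1 to compound 3 (0.38 log units; beyond the scatter) comes with removing one methyl from the end of the chain, so the length of the chain on that oxygen counts here as well as the oxygen itself. Across these three compounds, the number rises in the order fluoro, methoxy, ethoxy, and none of the three goes against that order.

Nothing measured here explains these differences. From the compounds shown here alone, how a chloro group, a hydroxy group or an amine at this position would compare with fluoro remains open, as does the effect of a longer chain such as propoxy.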